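Working notes: from compound 1 to compound 4

The source may hold more compounds than are shown below. What is called first, only, known or untested is meant among the compounds shown, and "the series" means these compounds.

compound 1 `COc1ccccc1/C=c1/[nH]c(=O)/c(=C\c2cccc(Cl)c2Cl)[nH]c1=O` — a functional assay on BGC-823 cells (Homo sapiens) for cytotoxicity, read by CCK-8 assay, with a stated time of 72 h; a lower number here means a stronger inhibitor, a higher number a weaker inhibitor: "not active" (no number reported)
compound 2 `C=CCn1c(=O)/c(=C\c2cccc(Cl)c2Cl)[nH]c(=O)/c1=C\c1ccccc1OC` — this assay: 2200 nM
compound 3 `COc1ccccc1/C=c1\c(=O)[nH]/c(=C/c2cccc(Cl)c2Cl)c(=O)n1C` — this assay: 300 nM

Compound 1 has no single number in this assay; it is recorded only as inactive, so its standing is that of the weak end of the three. Among the measured compounds shown here, the one measured step, a 7.3-fold lower number from compound 2 to compound 3 (0.87 log units; beyond the scatter), concerns the group on the aromatic nitrogen and leaves the aryl groups untouched. Compound 4 `COc1ccccc1/C=c1/[nH]c(=O)/c(=C\c2ccccc2OC)[nH]c1=O` differs from compound 1 by 2-methoxyphenyl in place of 2,3-dichlorophenyl on a double-bonded chain carbon bound to an aromatic carbon. For the measured compounds named here, no measured step bears on this change, so neither its direction nor its size in this assay can be read from the data; the starting point itself carries no number. Compound 4 is therefore expected to give roughly 20000 nM in this assay, within 3000 nM to 100000 nM, with a real chance that only inactivity is reported again.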

Compound 4, half-maximal inhibitory concentration: "not active" (no number reported)
No number was reported for compound 4, so the estimate cannot be set against anything.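

Compound 1 and compound 4 both stand without a number, so no step can be read between them. Going by these compounds, how 2-methoxyphenyl and 2,3-dichlorophenyl compare in potency remains open. No evidence bears on this result.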